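The source may hold more compounds than are shown below. What is called first, only, known or untested is meant among the compounds shown, and "the series" means these compounds.

Measured so far:
compound 1, `Cc1ccc(NC(=O)c2c(O)c3cccnc3n(-c3ccccc3)c2=O)cc1`: -3.5%
compound 2, `Cc1cccc(NC(=O)c2c(O)c3cccnc3n(-c3ccccc3)c2=O)c1`: 14.2%

Going by the values given here, in a functional assay on the whole organism for inhibition, with Rattus norvegicus as the target, read by paw edema, at a dose of 100 mg/kg by the oral route (on this read-out lower numbers stand for less inhibition and higher numbers for more inhibition at the one dose given (going by the name of the read-out)), compound 2 stands highest of the two numbers; the only other number, compound 1, lies below it by a number 17.7 percentage points higher from compound 1 to compound 2 (beyond the scatter), beyond the scatter. Compound 3, `COc1cccc(NC(=O)c2c(O)c3cccnc3n(-c3ccccc3)c2=O)c1`, differs from compound 2 by methoxy in place of methyl on an aromatic carbon. Among the compounds with values here, the one measured step concerns where a methyl sits on the ring and carries no information on methoxy in place of methyl; no measured step bears on this change. A step in this assay beyond the scatter is therefore not expected. For compound 3 the expected step is a number 2.2 percentage points lower from compound 2 to compound 3 (within the scatter). Compound 3 is estimated at 12%, within a range from -2% to 26%.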

Compound 3, a percentage reported as inhibition, in the whole organism at one dose (the size of the read-out at that dose, not a potency): 5.7%
Compound 3: middle estimate off by 6.3 percentage points, on the high side; the measured number falls inside the stated range.
By their numbers in this assay, from the lowest: compounds 1, 3 and 2 (each within the scatter of the next, the first and the last beyond it).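

In this assay, methoxy in place of methyl on this aromatic carbon gives a number 8.5 percentage points lower from compound 2 to compound 3 (within the scatter), so the added oxygen does not separate compound 3 from compound 2. The 3-methoxyphenyl amide also gives a number 9.2 percentage points higher from compound 1 to compound 3 (within the scatter), which leaves compound 3 unresolved from both methyl compounds, even though those two differ from each other beyond the scatter. No supporting data bear on these numbers.

Still open, as far as these compounds go, is whether an amine, a carboxylic acid or a longer chain such as ethoxy at this place would move the read-out beyond the scatter from compound 2. Also open, from the compounds shown here alone, is how these compounds would compare at other doses.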